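Replacing Dimethylamino with Hydroxy in Compound 1

A few compounds are considered here, and "the series" means these few. Any claim that something is new, unique, unknown or untested is made for them only; others in the source may bear on it.

In a functional assay on HCT-116 cells (Homo sapiens) for cytotoxicity, read by MTT assay, with a stated time of 3 days (on this read-out lower numbers stand for stronger inhibition and higher numbers for weaker inhibition), compound 1 `CN(C)Cc1ccc(/C=N/Nc2ncnc3sc(C(C)(C)C)cc23)cc1` gives 0.128 ug/mL. Compound 3 `CC(C)N1Cc2ccc(/C=N/Nc3ncnc4sc(C(C)(C)C)cc34)cc2C1` gives 0.206 ug/mL, and these two values lie within the usual scatter of each other. Compound 2 `CC(C)(C)c1cc2c(N/N=C/c3ccc(CN)cc3)ncnc2s1` gives 0.334 ug/mL, so compound 1 sits at the low end of this small set, a place it shares with compound 3.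

Compound 4 `CC(C)(C)c1cc2c(N/N=C/c3ccc(CO)cc3)ncnc2s1` has not yet been measured. It differs from compound 1 by one change: hydroxy in place of dimethylamino on a saturated chain carbon bound to an aromatic carbon. The rest of the structure is the same in both compounds.

Within the data shown here, one measured step bears on this directly, a 2.6-fold higher number from compound 1 to compound 2 (0.42 log units; beyond the scatter), which replaces dimethylamino with amino at that carbon. It is a modest step, beyond the scatter, toward weaker inhibition. Among the measured compounds shown here, no measured compound carries hydroxy, so this single step is a loose guide. On the strength of that step alone, a modest move in the same direction is expected, and the expected step is a 3.1-fold higher number from compound 1 to compound 4 (0.49 log units; beyond the scatter). For compound 4 the estimated value is 0.4 ug/mL, with an expected range from 0.15 ug/mL to 1.2 ug/mL.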

Compound 4, half-maximal inhibitory concentration: 0.665 ug/mL
For compound 4 the middle estimate is 1.7-fold (0.22 log units) below the measured one; the measured number falls inside the stated range.
By their numbers in this assay, from the lowest: compounds 1, 3, 2 and 4 (each within the scatter of the next, the first and the last beyond it).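

The change to hydroxy at this saturated chain carbon bound to an aromatic carbon gives a 5.2-fold higher number from compound 1 to compound 4 (0.72 log units; beyond the scatter) in this assay and, like the change to amino, lies beyond the scatter toward weaker inhibition. The drop on removing dimethylamino therefore no longer rests on a single replacement: among compound 1, compound 2 and compound 4, both replacements give higher numbers than dimethylamino, which stands apart from them at this position. Yet a 2.0-fold higher number from compound 2 to compound 4 (0.30 log units; within the scatter) stays within the scatter, so amino and hydroxy cannot be told apart here, and the presence of a nitrogen in the replacing group brings no measurable advantage.

As far as these compounds go, it remains open whether a group such as diethylamino, methoxy or a longer chain ending in an amine would keep a value close to that of compound 1 or would instead lie with compound 2 and compound 4. No measurement at hand gives a reason for these steps.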